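Series notes: aryl swap at the core from compound 2 to compound 3

The source may hold more compounds than are shown below. What is called first, only, known or untested is meant among the compounds shown, and "the series" means these compounds.

The shared core carries a cyclohexyl-substituted bicyclic group and an aryl ring on the six-membered aromatic ring with two nitrogens. Compound 1 `Fc1ccc(-c2cn3ccnc3c(-c3ccc4ncn(C5CCCCC5)c4c3)n2)cc1` is the fluoro member; in a functional assay on M14 cells (Homo sapiens) for inhibition, read by sulforhodamine B assay, with a stated time of 48 h, tested at 10 uM (a higher number here means more inhibition at the concentration tested (going by the name of the read-out), a lower number less inhibition), compound 1 gives 2.98%. Within the data shown here, compound 2 `Brc1ccc(-c2cn3ccnc3c(-c3ccc4ncn(C5CCCCC5)c4c3)n2)cc1` is the bromo member; in this assay compound 2 gives 26.9%, the highest of the two numbers so far, the only measured step being a number 23.9 percentage points higher from compound 1 to compound 2 (beyond the scatter).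

Compound 3 `Fc1ccccc1-c1cn2ccnc2c(-c2ccc3ncn(C4CCCCC4)c3c2)n1` differs from compound 2 in one place: 2-fluorophenyl in place of 4-bromophenyl on an aromatic carbon. Among the measured compounds shown here, the step from compound 1 to compound 2 bears on this change in reverse, since fluoro again replaces bromo, and that step was worth a number 23.9 percentage points higher from compound 1 to compound 2 (beyond the scatter); no measured pair covers the move of the fluorine within the phenyl ring, so that part of the change is unsupported by the data. The expected step is therefore a fall of roughly the same size, a number 19.9 percentage points lower from compound 2 to compound 3 (beyond the scatter), landing near the level of compound 1. For compound 3 the estimate in this assay is 7%, with a range from 0% to 25%.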

Compound 3, a percentage reported as inhibition, at one concentration (the size of the read-out at that concentration, not a potency): 2.92%
Compound 3: middle estimate off by 4.1 percentage points, on the high side; the range from low to high includes it.
By their numbers in this assay, from the lowest: compounds 3 and 1 (each within the scatter of the next); then compound 2.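

In this assay, the change from 4-bromophenyl to 2-fluorophenyl gives a number 24 percentage points lower from compound 2 to compound 3 (beyond the scatter), while the change from 4-fluorophenyl to 2-fluorophenyl gives a number 0.1 percentage points lower from compound 1 to compound 3 (within the scatter), so moving the fluorine around the phenyl ring makes no readable difference in this pair. Across these three compounds, the two fluorophenyl members, compound 1 and compound 3, cannot be told apart, and only compound 2, with its 4-bromophenyl group, stands clear of both, with no listed compound going against this split. Nothing available here explains why the bromo member stands apart from the two fluoro members.

As far as these compounds go, it remains open whether the level of compound 2 depends on the bromine sitting at the 4-position, which a 2-bromophenyl member would test directly. From the compounds shown here alone, it also remains open how an unsubstituted phenyl, a 4-chlorophenyl or a 4-methoxyphenyl group would read at this aromatic carbon, and whether any such group would go beyond compound 2 in this assay.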